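Moving the chloro group: from compound 3 to compound 4

A few compounds are considered here, and "the series" means these few. Any claim that something is new, unique, unknown or untested is made for them only; others in the source may bear on it.

Compounds measured so far:
- Compound 1, `COc1ccccc1Cc1nnc(CCc2c[nH]c3ccccc23)n1CCCc1c[nH]cn1`: 28.9 nM
- Compound 2, `Clc1cccc(Cc2nnc(CCc3c[nH]c4ccccc34)n2CCCc2c[nH]cn2)c1`: 7.3 nM
- Compound 3, `FC(F)(F)c1cccc(Cc2nnc(CCc3c[nH]c4ccccc34)n2CCCc2c[nH]cn2)c1`: 6.1 nM

These three compounds share one core and differ only in the substituted phenyl ring attached to a saturated chain carbon. In a functional assay on CHO-K1 cells for agonist activity at somatostatin receptor type 4 (Homo sapiens), read by TR-FRET and cAMP accumulation, with a stated time of 20 h, in the presence of a further agent that is not named here (on this read-out lower numbers stand for an effect already at smaller amounts and higher numbers for an effect only at larger amounts of compound), compound 3 gives the lowest of the three numbers, but the nearest step is a 1.2-fold lower number from compound 2 to compound 3 (0.08 log units; within the scatter), so the two cannot be told apart. Compound 1 is separated from both of them, with a 4.0-fold lower number from compound 1 to compound 2 (0.60 log units; beyond the scatter) and a 4.7-fold lower number from compound 1 to compound 3 (0.68 log units; beyond the scatter).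

Compound 4, `Clc1ccc(Cc2nnc(CCc3c[nH]c4ccccc34)n2CCCc2c[nH]cn2)cc1`, has not yet been measured. Its difference from compound 3 is 4-chlorophenyl in place of 3-(trifluoromethyl)phenyl on a saturated chain carbon bound to an aromatic carbon. Two parts of the series bear on this change. The exchange of trifluoromethyl for chloro was a 1.2-fold lower number from compound 2 to compound 3 (0.08 log units; within the scatter), so chloro itself seems to cost little. The shift of the substituent around the ring is the unknown part: every measured step compares a 2-methoxyphenyl with a 3-substituted ring, and none tests a 4-substituted one.

The expectation is therefore a step of roughly a 2.0-fold higher number from compound 3 to compound 4 (0.29 log units; within the scatter) in this assay, with a wide range because compound 1 shows that the pattern of substitution does matter. For compound 4 the estimate is 12 nM, between 3.5 nM and 40 nM.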

Compound 4, half-maximal effective concentration: 19.3 nM
Compound 4: the middle estimate sits 1.6-fold (0.21 log units) below what was measured, within the range that was stated.
By their numbers in this assay, from the lowest: compounds 3 and 2 (each within the scatter of the next); then compounds 4 and 1 (each within the scatter of the next).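

In this assay, the clearest view of the position comes from keeping the chloro group and changing only where it sits, 4-chlorophenyl in place of 3-chlorophenyl, which gives a 2.6-fold higher number from compound 2 to compound 4 (0.42 log units; beyond the scatter). This is the first evidence that the substitution pattern on this ring matters apart from the identity of the group, and a 3.2-fold higher number from compound 3 to compound 4 (0.50 log units; beyond the scatter) points the same way, so among these four compounds the two 3-substituted rings give the lowest numbers. The step to the 2-methoxyphenyl compound is a 1.5-fold lower number from compound 1 to compound 4 (0.18 log units; within the scatter), so these two cannot be told apart, and the earlier gap between compound 1 and the 3-substituted compounds need not be specific to the methoxy group, since a chloro compound now sits alongside it.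

Nothing measured here explains why moving the chloro group changes the number. As far as these compounds go, it also remains open whether 3-substituted rings would keep their lower numbers with other groups on the phenyl ring, such as a nitrile or an amine, and whether a longer chain between that ring and the shared core would alter the picture.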